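Naphthyl Gives Way to Chlorophenyl on the Amide Carbonyl

The source may hold more compounds than are shown below. What is called first, only, known or untested is meant among the compounds shown, and "the series" means these compounds.

Compound 3 `O=C(Nc1cc(Sc2ncn[nH]2)c(O)c2ccccc12)c1ccc2ccccc2c1` stands highest of the three compounds measured. In an assay on isolated protein for inhibition of RAC-alpha serine/threonine-protein kinase (Homo sapiens), read by fluorescence, with a stated time of 30 min, tested at 10 uM (on this read-out lower numbers stand for less inhibition and higher numbers for more inhibition at the one concentration tested (going by the name of the read-out)), compound 3 gives 41.6%, compound 1 `O=C(Nc1cc(Sc2ncn[nH]2)c(O)c2ccccc12)c1cccc([N+](=O)[O-])c1` gives 29.3%, and compound 2 `Cc1nnc(Sc2cc(NC(=O)c3ccc(Cl)cc3)c3ccccc3c2O)s1` gives 8.48%. For the measured compounds named here, the one measured step that bears on the change ahead is a number 12.3 percentage points higher from compound 1 to compound 3 (beyond the scatter), in which naphthalen-2-yl replaced 3-nitrophenyl. Compound 4 `O=C(Nc1cc(Sc2ncn[nH]2)c(O)c2ccccc12)c1ccc(Cl)cc1` differs from compound 3 by 4-chlorophenyl in place of naphthalen-2-yl on a carbonyl carbon. Because a number 12.3 percentage points higher from compound 1 to compound 3 (beyond the scatter) showed inhibition rising when the two-ring group entered, a return to a single ring is expected to lower it by a modest amount. Compound 2 carries the same 4-chlorophenyl but differs elsewhere too, so its value only hints at the lower side. Compound 4 is therefore expected to give 22% in this assay, within a range from 5% to 40%. The expected step is a number 19.6 percentage points lower from compound 3 to compound 4 (beyond the scatter).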

Compound 4, a percentage reported as inhibition, at one concentration (the size of the read-out at that concentration, not a potency): 50.1%
Compound 4: the middle estimate sits 28.1 percentage points below what was measured; the measured number lies above the stated range.
By their numbers in this assay, from the lowest: compound 2; then compound 1; then compounds 3 and 4 (each within the scatter of the next).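

In this assay the two-ring naphthalen-2-yl on this carbonyl carbon is not needed to keep the number, since 4-chlorophenyl in its place gives a number 8.5 percentage points higher from compound 3 to compound 4 (within the scatter) and the two groups cannot be told apart here. The same 4-chlorophenyl stands clear of 3-nitrophenyl with a number 20.8 percentage points higher from compound 1 to compound 4 (beyond the scatter) and the group on the sulfur also counts, as 1H-1,2,4-triazol-5-yl in place of 5-methyl-1,3,4-thiadiazol-2-yl gives a number 41.6 percentage points higher from compound 2 to compound 4 (beyond the scatter) here. Nothing measured here accounts for these steps.

On these data alone, whether an aminophenyl or a carboxyphenyl on the same carbonyl carbon would hold the number stays open. The single tested concentration also leaves the potency of these compounds open.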